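Swapping fluoro for cyano on the benzyl arm

The source may hold more compounds than are shown below. What is called first, only, known or untested is meant among the compounds shown, and "the series" means these compounds.

Compound 1 `O=c1ccoc2cc(OCc3cn(Cc4cccc(F)c4)nn3)ccc12` belongs to a small set of three close relatives tested in a functional assay on SGC-7901 cells (Homo sapiens) for cytotoxicity, read by MTT assay, with a stated time of 48 h; on this read-out lower numbers stand for stronger inhibition and higher numbers for weaker inhibition. In this assay compound 1 gives > 100000 nM, which is a limit of the assay rather than a measured number. Compound 2 `O=c1ccoc2cc(OCc3cn(Cc4ccccc4Br)nn3)ccc12` likewise stops at the limit > 100000 nM. Compound 3 `O=c1ccoc2cc(OCc3cn(Cc4ccc(Cl)cc4)nn3)ccc12` also gives only the limit > 100000 nM. Because every value so far sits at the limit of > 100000 nM in this assay, at which 3 of the 3 values shown sit, none of the steps among these three can be sized: a step that the two limits leave unreadable from compound 1 to compound 2, a step that the two limits leave unreadable from compound 1 to compound 3 and a step that the two limits leave unreadable from compound 2 to compound 3. So far the set shows only that changing the halogen and its position on the benzyl ring has not brought any of the compounds into the measurable range.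

Compound 4 `N#Cc1cccc(Cn2cc(COc3ccc4c(=O)ccoc4c3)nn2)c1` differs from compound 1 by cyano in place of fluoro on an aromatic carbon. Within the data shown here, no measured step touches this kind of change, and the three steps that are known are all unreadable, so there is no basis for expecting a shift in either direction beyond the scatter. Compound 4 is therefore expected to give about 100000 nM, within a range from 40000 nM to 300000 nM, and most likely to be reported again only as a limit. The expected step is a number no higher from compound 1 to compound 4 (the limit leaves the size open).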

Compound 4, half-maximal inhibitory concentration: > 100000 nM
Compound 4: only a limit was reported; the forecaster's own chance of this, stated with the estimate: 80%; the middle value sits exactly at the limit.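

Compound 4 is reported only as a limit, like compound 1, compound 2 and compound 3, so none of the new steps to compound 4 can be read: the limit of > 100000 nM in this assay, at which 4 of the 4 values shown sit.

The compounds shown leave open how far past that limit each one lies, and whether any change on the benzyl arm would give a measurable value in this assay.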